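Trichlorophenyl in Place of Nitrophenyl: What to Expect

The source may hold more compounds than are shown below. What is called first, only, known or untested is meant among the compounds shown, and "the series" means these compounds.

Measured so far:
compound 1, `O=C(/C=C/c1cccc(OCc2ccccc2)c1)c1ccc([N+](=O)[O-])cc1`, 17500 nM
compound 2, `Cc1ccc(C(=O)/C=C/c2cccc(OCc3ccccc3)c2)cc1`, 21700 nM

Both were tested in a functional assay on MCF7 cells (Homo sapiens) for cytotoxicity, read by MTT assay, with a stated time of 68 h; a lower number here means a stronger inhibitor, a higher number a weaker inhibitor. Compound 1 gives 17500 nM and holds the lowest of the two numbers, yet the step of a 1.2-fold higher number from compound 1 to compound 2 (0.09 log units; within the scatter) is within the scatter, so the two compounds are not told apart. Compound 2 gives 21700 nM. Compound 3, `O=C(/C=C/c1cccc(OCc2ccccc2)c1)c1ccc(Cl)c(Cl)c1Cl`, has not been measured. It differs from compound 1 in one place: 2,3,4-trichlorophenyl in place of 4-nitrophenyl on a carbonyl carbon. Within the data shown here, no measured step involves the group that enters. Among the measured compounds shown here, the only known step, a 1.2-fold higher number from compound 1 to compound 2 (0.09 log units; within the scatter), also changed the group on that carbonyl carbon and left the number within the scatter, so a change at this place is expected to do little. The expected step is a 1.2-fold lower number from compound 1 to compound 3 (0.07 log units; within the scatter). The estimate for compound 3 is 15000 nM, in a range from 5000 nM to 45000 nM.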

Compound 3, half-maximal inhibitory concentration: 2400 nM
Estimate against measurement, compound 3: 6.3-fold (0.80 log units) above, and the stated range ends above it.
By their numbers in this assay, from the lowest: compound 3; then compounds 1 and 2 (each within the scatter of the next).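

Judged by the earlier pair, this position looked indifferent, but in this assay the group on the carbonyl carbon can move the number well beyond the scatter. The 2,3,4-trichlorophenyl group brings a 7.3-fold lower number from compound 1 to compound 3 (0.86 log units; beyond the scatter) and a 9.0-fold lower number from compound 2 to compound 3 (0.96 log units; beyond the scatter) and so stands apart from both 4-nitrophenyl and 4-methylphenyl, which could not be told apart from each other. Nothing measured here explains why this group gives the lower number.

The chlorines enter together, so the compounds shown do not tell whether a single chlorine would give much of this step or whether all of them are needed. They also leave open how a phenyl ring carrying an amine or a carboxylic acid would behave on this carbonyl carbon.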